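Changing the aryl amide group on a shared core

The compounds below may be only part of what the source reports. "The series", "measured", "known", "first", "only" and "open" are said of these compounds alone.

Three measured compounds share one core and differ only in the aryl group on the amide carbonyl. In a functional assay on MCF7 cells (Homo sapiens) for antiproliferative activity, read by CCK-8 assay, with a stated time of 72 h (on this read-out higher numbers stand for weaker inhibition and lower numbers for stronger inhibition), compound 1 `O=C(Nc1cccc(-c2oc3cc(-c4ccc(F)cc4)ccc3c(=O)c2O)c1)c1ccc(Cl)cc1` gives 4730 nM. Compound 2 `O=C(Nc1cccc(-c2oc3cc(-c4ccc(F)cc4)ccc3c(=O)c2O)c1)c1ccc(F)cc1F` gives 13500 nM in this assay. Compound 3 `Cc1ccccc1C(=O)Nc1cccc(-c2oc3cc(-c4ccc(F)cc4)ccc3c(=O)c2O)c1` gives 2280 nM in this assay, the lowest of the three numbers and so the strongest inhibition shown. Compound 4 `O=C(Nc1cccc(-c2oc3cc(-c4ccc(F)cc4)ccc3c(=O)c2O)c1)c1cccc(F)c1` is not yet measured; its change from compound 3 is 3-fluorophenyl in place of 2-methylphenyl on a carbonyl carbon. Going by the values given here, two measured steps bear on this: going from compound 1 to compound 3 gave a 2.1-fold lower number from compound 1 to compound 3 (0.32 log units; beyond the scatter), and from compound 2 to compound 3 gave a 5.9-fold lower number from compound 2 to compound 3 (0.77 log units; beyond the scatter). In both, the 2-methylphenyl group of compound 3 gave a lower number than a phenyl carrying chlorine or fluorine. Replacing it with 3-fluorophenyl is therefore expected to raise the number modestly, a step of about a 2.4-fold higher number from compound 3 to compound 4 (0.38 log units; beyond the scatter). Compound 4 is estimated at 5500 nM in this assay, most likely between 2000 nM and 16000 nM.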

Compound 4, half-maximal inhibitory concentration: 5770 nM
The estimate for compound 4 lay 1.0-fold (0.02 log units) below the measured number; the range from low to high includes it.
By their numbers in this assay, from the lowest: compound 3; then compounds 1 and 4 (each within the scatter of the next); then compound 2.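

Compound 4 extends the pattern to a phenyl carrying a single fluorine: a 2.5-fold higher number from compound 3 to compound 4 (0.40 log units; beyond the scatter), so 2-methylphenyl now gives a lower number than all three halogen-bearing aryl groups shown. The result also separates the two fluorinated groups, with a 2.3-fold lower number from compound 2 to compound 4 (0.37 log units; beyond the scatter), while 3-fluorophenyl and 4-chlorophenyl cannot be told apart, with a 1.2-fold higher number from compound 1 to compound 4 (0.09 log units; within the scatter). Nothing measured here explains these differences.

Going by these compounds, what plain phenyl, 3-methylphenyl or 2-fluorophenyl would give remains open, so the lower number of compound 3 cannot yet be tied to the methyl group itself or to where it sits. Also open, on these data alone, is how this aryl group would behave carrying an amine or a carboxylic acid in place of the methyl or halogen.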